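Saturating the fused ring of a benzimidazole amide

The source may report more compounds than this note shows. Statements on the series, on what has been measured and on what is new or still open speak of the compounds shown alone.

Of the compounds shown here, three sharing one amide core have been measured in an assay on C3H 10T1/2 cells for inhibition of Sonic hedgehog protein (Mus musculus), read by a luciferase reporter; on this read-out lower numbers stand for stronger inhibition and higher numbers for weaker inhibition. Compound 1 `Cc1nc(C(F)(F)F)ccc1C(=O)Nc1ccc(Cl)c(-c2nc3ccccc3[nH]2)c1` gives 12 nM. Compound 2 `Cc1nc(C(F)(F)F)ccc1C(=O)Nc1ccc(Cl)c(-c2cc3ccccc3[nH]2)c1` gives 500 nM, and the step of a 42-fold higher number from compound 1 to compound 2 (1.62 log units; beyond the scatter) is large. Compound 3 `Cc1nc(C(F)(F)F)ccc1C(=O)Nc1ccc(Cl)c(-c2nc3ccccc3n2C)c1` gives 9 nM; the step of a 1.3-fold lower number from compound 1 to compound 3 (0.12 log units; within the scatter) stays within the scatter, while a 56-fold lower number from compound 2 to compound 3 (1.74 log units; beyond the scatter) is again large. Compound 3 thus stands at the low end of the three numbers, with compound 1 close to it and compound 2 far above.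

Compound 4 `Cc1nc(C(F)(F)F)ccc1C(=O)Nc1ccc(Cl)c(-c2nc3c(n2C)CCCC3)c1` differs from compound 3 by a group of 10 heavy atoms (8 carbon, 2 nitrogen; one five-membered aromatic ring with 2 hetero atoms, one six-membered non-aromatic ring of carbon only) in place of a group of 10 heavy atoms (8 carbon, 2 nitrogen; one five-membered aromatic ring with 2 hetero atoms, one six-membered aromatic ring of carbon only), on an aromatic carbon. Neither measured step bears directly on this change: the step from compound 1 to compound 2 exchanged the whole five-membered ring, and the step from compound 1 to compound 3 added a methyl on the ring nitrogen. The data give no guide for turning the six-membered aromatic ring into a non-aromatic one, so a modest weakening is expected, with wide uncertainty, as the step of a 4.4-fold higher number from compound 3 to compound 4 (0.65 log units; beyond the scatter). Compound 4 is therefore estimated at 40 nM, in the range 8 nM to 250 nM.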

Compound 4, half-maximal inhibitory concentration: 150 nM
Beside the measured number, compound 4's estimate is 3.8-fold (0.57 log units) below it, and the stated range covers the measured number.
By their numbers in this assay, from the lowest: compounds 3 and 1 (each within the scatter of the next); then compound 4; then compound 2.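

In this assay, the six-membered ring of this group turns out to matter: the swap keeps the heavy-atom count and the hydrogen-bond donor and acceptor counts, yet making that ring non-aromatic gives a 17-fold higher number from compound 3 to compound 4 (1.22 log units; beyond the scatter). The saturated group also falls short of the unmethylated benzimidazole, with a 13-fold higher number from compound 1 to compound 4 (1.10 log units; beyond the scatter), but it still outperforms the indole, with a 3.3-fold lower number from compound 2 to compound 4 (0.52 log units; beyond the scatter), so its loss is large but does not reach the level of the weakest compound. Nothing available explains why saturating this ring costs so much.

From the compounds shown here alone, it remains open whether a hydroxyl or an amine on the saturated ring could recover the lost strength. Going by these compounds, it is also open whether a hydrogen in place of the methyl on the ring nitrogen would change little here, as it does in the aromatic pair.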